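Chloro to methoxy on the pyrimidinone aryl of compound 2

The source may report more compounds than this note shows. Statements on the series, on what has been measured and on what is new or still open speak of the compounds shown alone.

Two members of this series have numbers in a functional assay on U-87MG ATCC cells for antiproliferative activity against U-87 MG (Homo sapiens), read by MTT assay, with a stated time of 48 h, tested at 50 uM (on this read-out lower numbers stand for a stronger effect and higher numbers for a weaker effect at the one concentration tested), so far. Compound 1 `COc1ccc(-c2nc(SCC(=O)c3sc(-c4ccccc4)nc3C)[nH]c(=O)c2C#N)cc1` gives 52.1% in this assay. Compound 2 `COc1ccc(-c2nc(C)c(C(=O)CSc3nc(-c4ccc(Cl)cc4)c(C#N)c(=O)[nH]3)s2)cc1` gives 48% in this assay; the number for compound 1 stands within the usual scatter of that for compound 2, so the two cannot be told apart on the present data. For the measured compounds named here, no pair of measured compounds differs in one place only, so no step has been measured directly.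

Compound 3 `COc1ccc(-c2nc(C)c(C(=O)CSc3nc(-c4ccc(OC)cc4)c(C#N)c(=O)[nH]3)s2)cc1` is not yet measured. It differs from compound 2 in one place: methoxy in place of chloro on an aromatic carbon. Going by the values given here, nothing in the measured pair speaks for a large effect of this exchange; both numbers so far sit in the same band, and compound 1, which also carries a methoxyphenyl on the shared core, gives 52.1%. The step from compound 2 to compound 3 in this assay is therefore expected to be small, with no direction beyond the scatter, as a number 2 percentage points higher from compound 2 to compound 3 (within the scatter). Compound 3 is estimated to give 50% in this assay, with a range from 35% to 65%.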

Compound 3, a percentage reported as activity, at one concentration (the size of the read-out at that concentration, not a potency): 32.6%
The estimate for compound 3 lay 17.4 percentage points above the measured number, outside the stated range (below it).
By their numbers in this assay, from the lowest: compound 3; then compounds 2 and 1 (each within the scatter of the next).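

In this assay, the exchange of 4-chlorophenyl for 4-methoxyphenyl on the shared core now has a directly measured effect, a number 15.4 percentage points lower from compound 2 to compound 3 (beyond the scatter), so this position is sensitive to the change, which the earlier pair, differing in two places, could not show. A second single exchange, this one on the other aryl group, moves the number the same way, a number 19.5 percentage points lower from compound 1 to compound 3 (beyond the scatter), so both comparisons place the compound with methoxy on both aryl groups at the stronger end of this small set. No measurement at hand accounts for either step.

Still open, as far as these compounds go, is whether a hydroxy, ethoxy or dimethylamino group at the same place on the aryl ring would lower the number further, leave it in the same band or raise it again. The read-out rests on a single concentration, so these compounds also leave open whether either step would carry over to a stronger or weaker effect at other concentrations.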